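From 4-ethylphenyl to phenethyl on the sulfur

The source may hold more compounds than are shown below. What is called first, only, known or untested is meant among the compounds shown, and "the series" means these compounds.

In a functional assay on HeLa cells (Homo sapiens) for inhibition, read by CCK-8 assay, with a stated time of 72 h, tested at 8 uM (a higher number here means more inhibition of growth at the concentration tested, a lower number less inhibition of growth), three compounds have been measured so far. Compound 1 `Nc1ccccc1NC(=O)/C=C/c1ccc(CSc2cccc(F)c2)cc1` gives 18.6%, compound 3 `CC(C)(C)c1ccc(SCc2ccc(C(=O)Nc3ccccc3N)cc2)cc1` gives 40.2%, and compound 2 `CCc1ccc(SCc2ccc(C(=O)Nc3ccccc3N)cc2)cc1` gives 71%. Compound 2 therefore stands highest of the three, with both gaps beyond the scatter.

Compound 4 `Nc1ccccc1NC(=O)c1ccc(CSCCc2ccccc2)cc1` has not yet been measured. Its change from compound 2 is phenethyl in place of 4-ethylphenyl on a sulfur whose other neighbour is a saturated chain carbon.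

Among the compounds with values here, only one measured step bears on this change, and only indirectly. That step is a number 30.8 percentage points lower from compound 2 to compound 3 (beyond the scatter), a large change with tert-butyl in place of ethyl on an aromatic carbon. It shows that a change in the group carried on the sulfur can move this assay well beyond the scatter. Within the data shown here, no measured step replaces 4-ethylphenyl with phenethyl, so the direction remains uncertain. With compound 2 already the highest at 71%, a fall is the more likely outcome, of a size similar to that one step.

The expected step is a number 26 percentage points lower from compound 2 to compound 4 (beyond the scatter), a fall that is estimated and not measured. For compound 4 the estimated value is 45%, with an expected range of 20% to 70%.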

Compound 4, percent growth inhibition at one concentration: 74.8%
Compound 4: the middle estimate sits 29.8 percentage points below what was measured, and the stated range ends below it.
By their numbers in this assay, from the lowest: compound 1; then compound 3; then compounds 2 and 4 (each within the scatter of the next).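

In this assay, phenethyl in place of 4-ethylphenyl on the sulfur gives a number 3.8 percentage points higher from compound 2 to compound 4 (within the scatter), so this place tolerates a phenyl ring carried on a saturated chain as well as the 4-ethylphenyl group of compound 2. Set against a number 30.8 percentage points lower from compound 2 to compound 3 (beyond the scatter), this shows that changes to the group on the sulfur do not all carry the same weight: a change to the substituent on the aromatic ring moved the read-out beyond the scatter, while this rearrangement of the same atoms into a different group did not. No measurement here accounts for either step.

The compounds shown leave open how much chain this place accepts, since a benzyl or a 3-phenylpropyl group on the sulfur would test a shorter and a longer link to the ring. They also leave open whether the phenethyl ring responds to substitution as the 4-ethylphenyl ring did, for example with a tert-butyl group, an amine or a carboxylic acid on it.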